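The source may hold more compounds than are shown below. What is called first, only, known or untested is meant among the compounds shown, and "the series" means these compounds.

In a functional assay on HCT-116 cells (Homo sapiens) for antiproliferative activity, read by MTT assay, with a stated time of 24 h (on this read-out higher numbers stand for weaker inhibition and lower numbers for stronger inhibition), compound 1 `C=CCOc1ccc2c(=O)c(-c3cc(OC)c(OC)cc3OC)coc2c1` gives 6600 nM while compound 2 `COc1cc(OC)c(-c2coc3cc(OCc4ccc(Br)cc4)ccc3c2=O)cc1OC` gives 1980 nM and compound 3 `COc1cc(OC)c(-c2coc3cc(OCc4ccc(Cl)cc4)ccc3c2=O)cc1OC` gives 4450 nM with the shared core unchanged. Compound 3 stands second highest of the three numbers: a 1.5-fold lower number from compound 1 to compound 3 (0.17 log units; within the scatter) stays inside the usual spread, whereas a 2.2-fold higher number from compound 2 to compound 3 (0.35 log units; beyond the scatter) goes past it.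

Next in the series is compound 4 `COc1cc(OC)c(-c2coc3cc(OCc4ccccc4Cl)ccc3c2=O)cc1OC` and the change is 2-chlorophenyl in place of 4-chlorophenyl on a saturated chain carbon bound to an oxygen on an aromatic ring with 2-chlorophenyl in place of 4-chlorophenyl on a saturated chain carbon bound to an oxygen on an aromatic ring. Going by the values given here, no measured step tests this swap directly, so the evidence is indirect. Among the compounds with values here, the steps that bear on it involve the same group: a 3.3-fold lower number from compound 1 to compound 2 (0.52 log units; beyond the scatter) is the largest so far and is modest, and a 2.2-fold higher number from compound 2 to compound 3 (0.35 log units; beyond the scatter) is also modest. Neither gives a direction for moving the chlorine, so no step beyond the scatter is expected in this assay and the expectation stays centred on compound 3.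

The estimated step is a 1.1-fold lower number from compound 3 to compound 4 (0.05 log units; within the scatter) and carries no firm direction. For compound 4 the estimated value is 4000 nM with an expected range from 1800 nM to 8500 nM in this read-out.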

Compound 4, half-maximal inhibitory concentration: 2450 nM
Compound 4: the middle estimate sits 1.6-fold (0.21 log units) above what was measured, within the range that was stated.
By their numbers in this assay, from the lowest: compounds 2, 4, 3 and 1 (each within the scatter of the next, the first and the last beyond it).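

In this assay the swap of 4-chlorophenyl for 2-chlorophenyl on the saturated chain carbon bound to an oxygen on an aromatic ring gives a 1.8-fold lower number from compound 3 to compound 4 (0.26 log units; within the scatter) and so is not resolved from the scatter; on this evidence, moving the chlorine has no readable effect. Compound 4 also cannot be separated from the bromo compound, with a 1.2-fold higher number from compound 2 to compound 4 (0.09 log units; within the scatter) as the step, even though a 2.2-fold higher number from compound 2 to compound 3 (0.35 log units; beyond the scatter) lies beyond the scatter, so compound 4 sits within reach of both halogenated neighbours and does not settle whether bromo and chloro truly differ here. Against the vinyl compound the result is clearer: a 2.7-fold lower number from compound 1 to compound 4 (0.43 log units; beyond the scatter) is beyond the scatter, as is the step to compound 2, while the step to compound 3 is not, so replacing vinyl with a halogenated phenyl does not give a uniform result across the three compounds.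

No measurement shown here accounts for any of these differences. Still open, as far as these compounds go, is how the read-out would respond at this place to 3-chlorophenyl, to 2-bromophenyl, or to a longer chain ending in an amine or a carboxylic acid.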